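From ethyl to 2-bromoethenyl on a shared core

The source may report more compounds than this note shows. Statements on the series, on what has been measured and on what is new or still open speak of the compounds shown alone.

Compound 1 `CCc1cn([C@@H]2S[C@H](CO)[C@@H](O)[C@@H]2O)c(=O)[nH]c1=O`: > 100 ug/mL
Compound 2 `CCc1cn([C@H]2S[C@H](CO)[C@@H](O)[C@@H]2O)c(=O)[nH]c1=O`: > 100 ug/mL

In a functional assay on CCRF-HSB-2 cells (Homo sapiens) for antiproliferative activity (on this read-out lower numbers stand for stronger inhibition and higher numbers for weaker inhibition), compound 2 gives > 100 ug/mL, which is a limit and not a number. Compound 1 gives > 100 ug/mL, also a limit. Neither compound therefore has a true number to start from.

The next compound to be tested is compound 3 `O=c1[nH]c(=O)n([C@H]2S[C@H](CO)[C@@H](O)[C@@H]2O)cc1/C=C/Br`. It keeps the shared core but carries a new group: 2-bromoethenyl in place of ethyl on an aromatic carbon. In short, 2-bromoethenyl stands in place of ethyl on an aromatic carbon.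

Among the measured compounds shown here, the only measured step is a step that the two limits leave unreadable from compound 1 to compound 2. It concerns (the fact that compounds 1 and 2 differ only in the configuration as drawn), and it does not touch the group that changes now. For the measured compounds named here, no measured step therefore gives a size for this exchange. Only a move toward stronger inhibition could appear as a number in this assay, and the likeliest expectation is another limit. The expected a number no higher from compound 2 to compound 3 (the limit leaves the size open) is only a rough guess.

For compound 3 the estimated value is 100 ug/mL, with an expected range from 30 ug/mL to 200 ug/mL.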

Compound 3, half-maximal inhibitory concentration: > 100 ug/mL
Compound 3: a limit, no number; the forecaster's own chance of this, stated with the estimate: 70%; the middle value sits exactly at the limit.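

Compound 3 also ends at a limit, so no size can be read for the step from compound 2 to compound 3, nor for the step from compound 1 to compound 2: the limit of > 100 ug/mL in this assay, at which 3 of the 3 values shown sit. The compounds shown leave open whether ethyl or 2-bromoethenyl, or either drawn configuration, makes any difference to inhibition.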